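The compounds below may be only part of what the source reports. "The series", "measured", "known", "first", "only" and "open" are said of these compounds alone.

Working notes on the series, values from an ADME assay on microsomes from liver (Rattus norvegicus) for metabolic stability, read by LC-MS, using NADPH, with a stated time of 10 min, tested at 0.1 uM; a higher number here means faster removal of the compound, a lower number slower removal

compound 1 `O=C(NCCCCn1cccn1)c1cccc(C2SCC(=O)N2c2ccccn2)c1` gives 506 mL.min-1.g-1
compound 2 `O=C(NCCCCc1ccccc1)c1cccc(C2SCC(=O)N2c2cccc(-c3c[nH]nn3)c2)c1` gives 742 mL.min-1.g-1

On these numbers, compound 2 sits within the usual scatter of compound 1, so neither stands apart from the other. Going by the values given here, the two differ in more than one place, so no single-place step has been measured in this assay and the size of the next step rests on these two values alone.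

Compound 3 (`O=C(NCCCCc1ccccc1)c1cccc(C2SCC(=O)N2c2ccccn2)c1`) has not yet been measured. It keeps the rest of compound 2 and changes one group, on an amide-type nitrogen in a ring: a group of 6 heavy atoms (5 carbon, 1 nitrogen; one six-membered aromatic ring with 1 hetero atom) in place of a group of 11 heavy atoms (8 carbon, 3 nitrogen; one five-membered aromatic ring with 3 hetero atoms, one six-membered aromatic ring of carbon only), on an amide-type nitrogen in a ring is the counted difference. The entering pyridin-2-yl is already present in compound 1 (506 mL.min-1.g-1), and the remainder of compound 3 is shared with compound 2 (742 mL.min-1.g-1). No step beyond the scatter is therefore expected in either direction.

The expected change, a 1.1-fold lower number from compound 2 to compound 3 (0.04 log units; within the scatter), is an estimate that stays within the scatter. Compound 3 is estimated at 680 mL.min-1.g-1 in this assay, with an expected range from 300 mL.min-1.g-1 to 1500 mL.min-1.g-1 for the coming measurement.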

Compound 3, intrinsic clearance in microsomes: 1480 mL.min-1.g-1
For compound 3 the middle estimate is 2.2-fold (0.34 log units) below the measured one; the measured number falls inside the stated range.
By their numbers in this assay, from the lowest: compounds 1, 2 and 3 (each within the scatter of the next, the first and the last beyond it).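

In this assay, pyridin-2-yl in place of the group of 11 heavy atoms, which carries a five-membered aromatic ring with 3 hetero atoms and a six-membered aromatic ring of carbon only, gives a 2.0-fold higher number from compound 2 to compound 3 (0.30 log units; within the scatter); this first single-place reading on the amide-type nitrogen in a ring therefore stays within the scatter, even with the counted difference in group size. Going by these compounds alone, the other end of the molecule gives the first single-place step beyond the scatter: phenyl in place of 1H-pyrazol-1-yl on a saturated chain carbon, four bonds along the chain from an amide-type nitrogen, gives a 2.9-fold higher number from compound 1 to compound 3 (0.47 log units; beyond the scatter), a modest step. Nothing at hand accounts for either step.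

As far as these compounds go, each place rests on one pair, so it remains open whether the chain step holds with a group other than pyridin-2-yl on the amide-type nitrogen in a ring. Also open, from the compounds shown here alone, is how a carboxylic acid or an amine in place of phenyl on that chain, or a shorter chain, would read in this assay.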